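A few compounds are considered here, and "the series" means these few. Any claim that something is new, unique, unknown or untested is made for them only; others in the source may bear on it.

Measured compounds:
Compound 1, `Cc1nc2c(Br)c(Br)c(Br)c(Br)c2n1CC#N`, gives 45% in a functional assay on CCRF-CEM cells (Homo sapiens) for cytotoxicity, read by MTT assay, with a stated time of 24 h, tested at 10 uM; on this read-out higher numbers stand for a weaker effect at the one concentration tested and lower numbers for a stronger effect.
Compound 2, `Cc1nc2c(Br)c(Br)c(Br)c(Br)c2n1CCCCC#N`, gives 92% in this assay.
Compound 3, `Cc1nc2c(Br)c(Br)c(Br)c(Br)c2n1CCC#N`, gives 84% in this assay.

Compound 3 stands second highest of the three numbers in this assay. Its nearest neighbour is compound 2, and the step of a number 8 percentage points lower from compound 2 to compound 3 (within the scatter) lies within the scatter, so the two cannot be ordered. Its furthest neighbour is compound 1, and the step of a number 39 percentage points higher from compound 1 to compound 3 (beyond the scatter) is large and beyond the scatter.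

Compound 4, `Cc1nc2c(Br)c(Br)c(Br)c(Br)c2n1CCCC#N`, has not yet been measured. Against compound 3 it differs by cyanomethyl in place of cyano on a saturated chain carbon, two bonds along the chain from an aromatic nitrogen.

For the measured compounds named here, two measured steps bear on this change. The step of a number 39 percentage points higher from compound 1 to compound 3 (beyond the scatter) shows a large rise when the chain is lengthened from the shortest member, and the step of a number 47 percentage points higher from compound 1 to compound 2 (beyond the scatter) shows a comparable rise for the longest chain. Between compound 3 and compound 2, however, the step of a number 8 percentage points lower from compound 2 to compound 3 (within the scatter) stays within the scatter, so further lengthening beyond compound 3 has shown no effect that can be resolved. Compound 4 sits between these two in chain length, so no step beyond the scatter is expected in this assay.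

The estimated step for compound 4 is a number 4 percentage points higher from compound 3 to compound 4 (within the scatter). Compound 4 is therefore expected to give about 88% in this assay, within a range of 76% to 98%.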

Compound 4, a percentage reported as activity, at one concentration (the size of the read-out at that concentration, not a potency): 68%
Compound 4: middle estimate off by 20 percentage points, on the high side; measured number below the stated range.
By their numbers in this assay, from the lowest: compound 1; then compound 4; then compounds 3 and 2 (each within the scatter of the next).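

In this assay, lengthening the chain does not give a rise that simply levels off after compound 3: the step of a number 16 percentage points lower from compound 3 to compound 4 (beyond the scatter) runs against the earlier rise, while a number 23 percentage points higher from compound 1 to compound 4 (beyond the scatter) and a number 24 percentage points lower from compound 2 to compound 4 (beyond the scatter) set compound 4 apart from both the shortest and the longest chain. The size of one and the same lengthening therefore depends on the chain it is made on: the same change on two cores in this assay, a number 39 percentage points higher (beyond the scatter) from compound 1 to compound 3 and a number 24 percentage points higher (beyond the scatter) from compound 4 to compound 2, 15 percentage points apart, beyond the scatter of two such steps. The reverse change, shortening the chain, likewise differs from one chain to the next: the same change on two cores in this assay, a number 8 percentage points lower (within the scatter) from compound 2 to compound 3 and a number 23 percentage points lower (beyond the scatter) from compound 4 to compound 1, 15 percentage points apart, beyond the scatter of two such steps.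

The compounds shown leave open whether this uneven course continues with a longer chain than the 3-cyanopropyl group of compound 2, and whether an amine or a carboxylic acid in place of the nitrile would show the same dependence on chain length. Because each number is a read-out at a single concentration, they also leave open whether the stronger and weaker effects seen at that concentration would hold at any other: the same change on two cores in this assay, a number 8 percentage points lower (within the scatter) from compound 2 to compound 3 and a number 23 percentage points lower (beyond the scatter) from compound 4 to compound 1, 15 percentage points apart, beyond the scatter of two such steps.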